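Moving the phenyl from a methylene onto the sulfonamide nitrogen

The source may report more compounds than this note shows. Statements on the series, on what has been measured and on what is new or still open speak of the compounds shown alone.

Measured so far:
Compound 1, `CC(C)NS(=O)(=O)c1ccc2c(c1)C(n1ccccc1=O)=CC(C)(C)O2`: 1950 nM
Compound 2, `CC1(C)C=C(n2ccccc2=O)c2cc(S(=O)(=O)NCc3ccccc3)ccc2O1`: 1320 nM
Compound 3, `CC1(C)C=C(n2ccccc2=O)c2cc(S(=O)(=O)Nc3ccccc3)ccc2O1`: 13.2 nM

These three compounds share one core and differ only in the group on the sulfonamide nitrogen. In a functional assay with Rattus norvegicus as the target (on this read-out lower numbers stand for an effect already at smaller amounts and higher numbers for an effect only at larger amounts of compound), compound 2 gives 1320 nM, the second highest of the three numbers. Its nearest neighbour is compound 1, with a 1.5-fold lower number from compound 1 to compound 2 (0.17 log units; within the scatter). Its furthest is compound 3, with a 100-fold lower number from compound 2 to compound 3 (2.00 log units; beyond the scatter), and the same group change from compound 1 gives a 150-fold lower number from compound 1 to compound 3 (2.17 log units; beyond the scatter).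

Compound 4, `CN(c1ccccc1)S(=O)(=O)c1ccc2c(c1)C(n1ccccc1=O)=CC(C)(C)O2`, is still to be measured. It differs from compound 2 in one place: methyl(phenyl)amino in place of benzylamino on a sulfonyl sulfur. The new group keeps the same atoms as the benzylamino group but puts the phenyl onto the nitrogen, as in compound 3, while a methyl now sits where compound 2 and compound 3 carry a hydrogen. The step from compound 2 to compound 3 is the one that bears most on this change, and it was large in the direction of lower numbers. Within the data shown here, no measured step shows what the methyl in place of the hydrogen does, so the expectation is wider than that step alone.

For compound 4 a large step toward lower numbers is expected, a 13-fold lower number from compound 2 to compound 4 (1.12 log units; beyond the scatter), but smaller than the step to compound 3. The estimate for compound 4 in this assay is 100 nM, within a range from 15 nM to 1000 nM.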

Compound 4, half-maximal effective concentration: 9.77 nM
Estimate against measurement, compound 4: 10-fold (1.01 log units) above; the whole stated range lies above it.
By their numbers in this assay, from the lowest: compounds 4 and 3 (each within the scatter of the next); then compounds 2 and 1 (each within the scatter of the next).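

In this assay the step of a 140-fold lower number from compound 2 to compound 4 (2.13 log units; beyond the scatter) comes from a swap that keeps the same atoms and only joins them differently, so the phenyl on the sulfonamide nitrogen now holds its low number even with no hydrogen left there. Among these compounds, the step of a 1.4-fold lower number from compound 3 to compound 4 (0.13 log units; within the scatter) stays within the scatter, which shows for the first time that a methyl can replace that hydrogen with no measurable difference in this read-out, and the hydrogen in compound 3 is therefore not required for a low number here. The step of a 200-fold lower number from compound 1 to compound 4 (2.30 log units; beyond the scatter) points the same way, so among these four compounds the two with a phenyl directly on the nitrogen stand far from the two with isopropyl or benzyl there, and nothing at hand explains this gap.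

A single methyl is the only group shown on the nitrogen alongside the phenyl, so an ethyl or a longer chain in that place remains an open case. Also open, as far as these compounds go, are a methyl(benzyl)amino group, which would test the methyl without the phenyl on the nitrogen, and a chlorine or methoxy on the phenyl ring.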